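This account rests on a few compounds, and the source may have more. Where it says the series, first, only, none or still open, it means among the compounds named here.

Working notes on the series in a functional assay on CHO cells for agonist activity at Free fatty acid receptor 1 (Homo sapiens), read by FLIPR and calcium flux, in the presence of a further agent that is not named here; a higher number here means that more compound is needed for the effect, a lower number that less compound is needed.

Of the compounds shown here, three have numbers so far. Compound 2 `O=C(O)CCc1ccc(OCc2nc(-c3ccccc3)no2)cc1` gives 1130 nM in this assay. Compound 1 `O=C(O)CCc1ccc(OCc2nc(-c3ccccc3Cl)no2)cc1` gives 1200 nM. The change between them is chloro in place of hydrogen on an aromatic carbon and its step is a 1.1-fold higher number from compound 2 to compound 1 (0.03 log units; within the scatter). Compound 3 `COc1cccc(-c2noc(COc3ccc(CCC(=O)O)cc3)n2)c1` gives 2670 nM, the highest number of the three; the step of a 2.2-fold higher number from compound 1 to compound 3 (0.35 log units; beyond the scatter) and the step of a 2.4-fold higher number from compound 2 to compound 3 (0.37 log units; beyond the scatter) are both modest, and the change from compound 2 to compound 3 is methoxy in place of hydrogen on an aromatic carbon.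

Compound 4 `COc1cccc(-c2noc(COc3ccc(CCC(=O)O)cc3Cl)n2)c1` is not yet measured. It differs from compound 3 by chloro in place of hydrogen on an aromatic carbon. This is the same kind of change as from compound 2 to compound 1, where chloro enters on an aromatic carbon ortho to a large group; in compound 4, however, the chloro enters on the other six-membered ring of the core, ortho to a large group and meta to a 2-carboxyethyl group, so the surroundings of the place are not the same. The two cores differ as stated for compound 2 and compound 3.

With one precedent, the expectation for compound 4 rests on compound 2 to compound 1, where the chloro left the number essentially unchanged because a 1.1-fold higher number from compound 2 to compound 1 (0.03 log units; within the scatter) lies within the scatter. The step from compound 3 to compound 4 is therefore expected to be small, a 1.1-fold lower number from compound 3 to compound 4 (0.03 log units; within the scatter), with the range widened since the chloro sits on a different ring. Compound 4 is estimated at 2500 nM, between 900 nM and 7000 nM.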

Compound 4, half-maximal effective concentration: 3000 nM
Beside the measured number, compound 4's estimate is 1.2-fold (0.08 log units) below it; low and high end bracket the measured number.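

In this assay the new step is a 1.1-fold higher number from compound 3 to compound 4 (0.05 log units; within the scatter), so chloro in place of hydrogen on an aromatic carbon again leaves the number essentially where it was. Set beside the earlier case, the change reads the same on both cores: the same change on two cores in this assay, a 1.1-fold higher number (0.03 log units; within the scatter) from compound 2 to compound 1 and a 1.1-fold higher number (0.05 log units; within the scatter) from compound 3 to compound 4, 1.1-fold (0.02 log units) apart, within the scatter of two such steps. This shows that in these two pairs the chloro can be added without a step beyond the scatter, but it does not show that one position carries over from core to core, since the chloro of compound 4 stands on the other six-membered ring from the chloro of compound 1, and two steps this small give no measure of how far the result extends to other cores or other places.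

The compounds shown leave open whether a different group in the place of this chloro, such as trifluoromethyl or an amine, would also leave the number where it is, and whether chloro on both six-membered rings together would do the same. They also leave open whether the chloro step holds when the 2-carboxyethyl group gives way to a longer chain ending in a carboxylic acid.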